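A few compounds are considered here, and "the series" means these few. Any claim that something is new, unique, unknown or untested is made for them only; others in the source may bear on it.

Compound 1 `CCC/N=C(/NC#N)NCCCCn1nc(-c2ccccc2)ccc1=O` carries a cyanoguanidine on a four-carbon chain attached to the shared core. In a functional assay on the whole organism (stomach) with Rattus norvegicus as the target (on this read-out higher numbers stand for an effect only at larger amounts of compound and lower numbers for an effect already at smaller amounts), compound 1 gives only a limit, > 100 mg/kg, not a number. Compound 2 `O=c1ccc(-c2ccccc2)nn1CCCCNC(=S)Nc1cccc2ccccc12` also gives only a limit, > 100 mg/kg. Compound 3 `C/N=C(/NC#N)NCCCCn1nc(C)ccc1=O` likewise stops at a limit, > 100 mg/kg. Within the data shown here, all three sit at the limit of > 100 mg/kg in this assay, at which 3 of the 3 values shown sit, so no measured step can be sized.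

Compound 4 `C/N=C(\NC#N)NCCCCn1nc(-c2ccccc2)ccc1=O` differs from compound 1 by a group of 6 heavy atoms (3 carbon, 3 nitrogen; no ring) in place of a group of 8 heavy atoms (5 carbon, 3 nitrogen; no ring), on an amine nitrogen. Among the measured compounds shown here, no measured pair with the same change exists, so the step is estimated without a precedent in this assay. Given that compound 3, which carries the same smaller cyanoguanidine group, stays at > 100 mg/kg, the expected step from compound 1 to compound 4 is a step that the limit leaves unreadable from compound 1 to compound 4, none beyond the scatter. Compound 4 is therefore estimated at 150 mg/kg, within a range of 50 mg/kg to 500 mg/kg, most probably again reported only as a limit.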

Compound 4, dose for half-maximal effect: 32.4 mg/kg
Beside the measured number, compound 4's estimate is 4.6-fold (0.67 log units) above it; measured number below the stated range.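

In this assay, the amine nitrogen on the saturated chain proves sensitive to this change: the group of 6 heavy atoms in place of the group of 8 heavy atoms gives an at least 3.0-fold lower number from compound 1 to compound 4 (0.48 log units; beyond the scatter). Among these compounds, compound 4 is the first compound with a number, 32.4 mg/kg. The step gives only a lower bound on the size of the change, since compound 1 stands at a limit: the limit of > 100 mg/kg in this assay, at which 3 of the 4 values shown sit.

As far as these compounds go, it remains open whether a hydrogen on that nitrogen in place of the group would lower the number further. Also open, from the compounds shown here alone, is whether a longer chain would keep the gain.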